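The source may hold more compounds than are shown below. What is called first, only, known or untested is meant among the compounds shown, and "the series" means these compounds.

Compound 1 `O=C(Cc1csc2nc(-c3ccc(Br)cc3)cn12)N/N=C/c1ccccc1O`: 16600 nM
Compound 2 `COc1cccc(OC)c1/C=N/NC(=O)Cc1csc2nc(-c3ccc(Br)cc3)cn12`: 93300 nM

In a functional assay on PC-3 cells (Homo sapiens) for inhibition, read by sulforhodamine B assay, with a stated time of 48 h (on this read-out higher numbers stand for weaker inhibition of growth and lower numbers for stronger inhibition of growth), compound 2 gives 93300 nM, the higher of the two numbers, so it is the weaker growth inhibitor of this pair. Compound 3 `O=C(Cc1csc2nc(-c3ccc(Br)cc3)cn12)N/N=C/c1ccc(Cl)cc1Cl` differs from it in one place: 2,4-dichlorophenyl in place of 2,6-dimethoxyphenyl on a carbon with a double bond to nitrogen. Among the compounds with values here, only one measured step bears on this change: a 5.6-fold higher number from compound 1 to compound 2 (0.75 log units; beyond the scatter). That modest step came with the arrival of 2,6-dimethoxyphenyl in place of 2-hydroxyphenyl, and compound 3 gives up that same 2,6-dimethoxyphenyl group. Within the data shown here, no measured compound yet carries 2,4-dichlorophenyl, so the size of the change remains uncertain. A modest move towards stronger inhibition is expected in this assay: a 3.1-fold lower number from compound 2 to compound 3 (0.49 log units; beyond the scatter). For compound 3, the estimated value is 30000 nM, within an expected range of 10000 nM to 90000 nM.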

Compound 3, concentration for total growth inhibition: > 100000 nM
Compound 3: only a limit was reported; the forecaster's own chance of this, stated with the estimate: 10%; at least 3.3-fold (0.52 log units) between middle value and limit.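

In this assay compound 3 gives only a limit, not a number: the limit of > 100000 nM in this assay, at which 1 of the 3 values shown sits. Replacing 2,6-dimethoxyphenyl with 2,4-dichlorophenyl on a carbon with a double bond to nitrogen gives an at least 1.0-fold higher number from compound 2 to compound 3 (0.03 log units; that floor lies within the scatter), so this pair cannot be ranked, and the expected gain in growth inhibition did not appear. Replacing 2-hydroxyphenyl with 2,4-dichlorophenyl gives an at least 6.0-fold higher number from compound 1 to compound 3 (0.77 log units; beyond the scatter), which means that both replacements now shown for the 2-hydroxyphenyl group, one with two methoxy groups and one with two chlorines, give weaker inhibition, leaving compound 1 the strongest of the three.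

Going by these compounds, how far compound 3 really lies beyond its limit remains unknown. On these data alone, it also remains open whether a 2-aminophenyl group or a 2-carboxyphenyl group at this place would keep the growth inhibition of compound 1.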